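The source may report more compounds than this note shows. Statements on the series, on what has been measured and on what is new or still open speak of the compounds shown alone.

Measured so far:
- compound 1, `O=C(/C=C/c1ccccc1)c1ccc(N2CCN(c3cccc(Cl)c3)CC2)cc1`, 14.1%
- compound 2, `Cc1ccc(N2CCN(c3ccc(C(=O)/C=C/c4ccccc4)cc3)CC2)cc1`, 2.85%

In a functional assay on the whole organism (strain Kunming) for inhibition, with Mus musculus as the target, with a stated time of 1 h, at a dose of 40 mg/kg by the oral route (on this read-out higher numbers stand for more inhibition at the one dose given (going by the name of the read-out) and lower numbers for less inhibition), compound 1 gives 14.1%, the higher of the two numbers; compound 2 sits a number 11.3 percentage points lower from compound 1 to compound 2 (beyond the scatter), and that step came with 4-methylphenyl in place of 3-chlorophenyl on an amine nitrogen in a ring.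

Compound 3, `O=C(/C=C/c1ccccc1)c1ccc(N2CCN(c3ccccc3)CC2)cc1`, is not yet measured. It differs from compound 1 by hydrogen in place of chloro on an aromatic carbon, so the shared core is kept and only the chloro on the ring attached to that nitrogen is lost.

For the measured compounds named here, the only measured step that touches this part of the molecule is a number 11.3 percentage points lower from compound 1 to compound 2 (beyond the scatter), where swapping the 3-chlorophenyl for another ring lowered inhibition beyond the scatter. Losing the chloro alone is a smaller change, so a drop is expected for compound 3 in this assay, of a size that may not exceed the scatter: a number 6.1 percentage points lower from compound 1 to compound 3 (within the scatter). Compound 3 is therefore estimated at 8%, between -3% and 19%.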

Compound 3, a percentage reported as inhibition, in the whole organism at one dose (the size of the read-out at that dose, not a potency): 3.71%
The estimate for compound 3 lay 4.3 percentage points above the measured number; the range from low to high includes it.
By their numbers in this assay, from the lowest: compounds 2 and 3 (each within the scatter of the next); then compound 1.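

In this assay, losing the chloro alone is enough to lower inhibition, with a number 10.4 percentage points lower from compound 1 to compound 3 (beyond the scatter); the earlier step had replaced the 3-chlorophenyl with a 4-methylphenyl, which changed both the group and where it sits on the ring. The phenyl and 4-methylphenyl rings cannot be told apart, with a number 0.9 percentage points higher from compound 2 to compound 3 (within the scatter), so among these three compounds only the 3-chlorophenyl ring stands out, and a methyl in the position named by 4-methylphenyl shows no measurable gain over hydrogen. Nothing available explains why the chloro matters here.

As far as these compounds go, it remains open whether the chloro needs this exact position, which a 4-chlorophenyl ring would test. From the compounds shown here alone, it is also open whether another group in the same place, such as bromo, methoxy or trifluoromethyl, would match or exceed the chloro.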